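Moving the carboxylic acid and removing chlorine in compound 3

This account rests on a few compounds, and the source may have more. Where it says the series, first, only, none or still open, it means among the compounds named here.

In an assay on HEK293 cells for positive allosteric modulation of metabotropic glutamate receptor 3 (Rattus norvegicus), read by thallium flux, with a stated time of 2.5 min (on this read-out higher numbers stand for larger maximal responses and lower numbers for smaller maximal responses), compound 1 `Cc1c(OCCCCOc2ccccc2C(=O)O)ccc(C(=O)CC2CCCC2)c1C` gives 28%, compound 2 `Cc1c(OCCCCOc2ccc(C(=O)O)cc2)ccc(C(=O)CC(C)C)c1C` gives 16.6% and compound 3 `Cc1c(OCCCCOc2ccc(C(=O)O)c(Cl)c2)ccc(C(=O)CC(C)C)c1C` gives 12%. Compound 3 sits at the low end of these three numbers: compound 2 lies within the scatter of it, whereas compound 1 lies beyond it. Compound 4 `Cc1c(OCCCCOc2ccccc2C(=O)O)ccc(C(=O)CC(C)C)c1C` arises from compound 3 through (2-carboxyphenyl in place of 4-carboxy-3-chlorophenyl on an oxygen on a saturated carbon). Going by the values given here, the one measured step that bears on this change, a number 4.6 percentage points lower from compound 2 to compound 3 (within the scatter), was within the scatter, so removing the chlorine alone promises little; the 2-carboxyphenyl group, however, is the one carried by compound 1, which gave 28%. Compound 4 is therefore expected to give 23% (range 13% to 33%), a step of a number 11 percentage points higher from compound 3 to compound 4 (beyond the scatter) that is estimated to exceed the scatter.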

Compound 4, largest response reached (reported as percent of maximum), in percent of the reference or control that the assay uses: 30.7%
For compound 4 the middle estimate is 7.7 percentage points below the measured one; measured number inside the range.
By their numbers in this assay, from the lowest: compounds 3 and 2 (each within the scatter of the next); then compounds 1 and 4 (each within the scatter of the next).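

In this assay, 2-carboxyphenyl on the oxygen gives a larger response than 4-carboxy-3-chlorophenyl (a number 18.7 percentage points higher from compound 3 to compound 4 (beyond the scatter)) and also than 4-carboxyphenyl (a number 14.1 percentage points higher from compound 2 to compound 4 (beyond the scatter)), so this group change, unlike the chloro step, exceeds the scatter. With 2-carboxyphenyl in place, isopropyl and cyclopentyl on the saturated chain carbon stay within the scatter of each other (a number 2.7 percentage points higher from compound 1 to compound 4 (within the scatter)). Nothing available here explains the gain from 2-carboxyphenyl. From the compounds shown here alone, it remains open whether a tetrazole in place of the carboxylic acid, or a longer chain in place of isopropyl, would keep this response.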